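A fluorine moved on the benzyl arm of a covalent warhead

The source may hold more compounds than are shown below. What is called first, only, known or untested is meant among the compounds shown, and "the series" means these compounds.

Compound 1 `C=C(Br)C(=O)Nc1cccc(/C=C2\SC(=O)N(Cc3cccc(F)c3)C2=O)c1` carries a (1-bromoethenyl)carbonyl amide on one aromatic ring and a 3-fluorobenzyl group on the ring nitrogen of the shared core. In a functional assay on FM3A cells (Mus musculus) for cytotoxicity, read by cell counting, with a stated time of 2 days (on this read-out higher numbers stand for weaker inhibition and lower numbers for stronger inhibition), compound 1 gives 690 nM, the lowest of the two numbers seen here. Compound 2 `Nc1cccc(/C=C2\SC(=O)N(Cc3cccc(F)c3)C2=O)c1` lacks the (1-bromoethenyl)carbonyl group, and in this assay compound 2 reaches only a limit, > 250000 nM. That step, an at least 360-fold higher number from compound 1 to compound 2 (2.55 log units; beyond the scatter), shows how much the warhead matters, in line with the limit of > 250000 nM in this assay, at which 1 of the 3 values shown sits. Compound 3 `C=C(Br)C(=O)Nc1ccc(/C=C2\SC(=O)N(Cc3ccc(F)cc3)C2=O)cc1` keeps the warhead and gives 4600 nM, a higher number than compound 1, but it differs from compound 1 in two places, so no single cause can be read from it.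

Compound 4 `C=C(Br)C(=O)Nc1cccc(/C=C2\SC(=O)N(Cc3ccc(F)cc3)C2=O)c1` differs from compound 1 by 4-fluorophenyl in place of 3-fluorophenyl on a saturated chain carbon bound to an amide-type nitrogen in a ring. Among the compounds with values here, no measured step isolates this change. Within the data shown here, the one step known, from compound 1 to compound 2, concerns the warhead, which compound 4 keeps, so it gives no direction here. A step within or only slightly beyond the scatter is therefore expected, perhaps toward a higher number as compound 3 hints. The estimate for compound 4 in this assay is 1200 nM, between 400 nM and 4000 nM, an expected step of a 1.7-fold higher number from compound 1 to compound 4 (0.24 log units; within the scatter).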

Compound 4, half-maximal inhibitory concentration: 920 nM
Beside the measured number, compound 4's estimate is 1.3-fold (0.12 log units) above it; the range from low to high includes it.
By their numbers in this assay, from the lowest: compounds 1 and 4 (each within the scatter of the next); then compound 3. At a limit, above all of these: compound 2.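

Moving the fluorine on the benzyl arm, 4-fluorophenyl in place of 3-fluorophenyl on a saturated chain carbon bound to an amide-type nitrogen in a ring, gives a 1.3-fold higher number from compound 1 to compound 4 (0.12 log units; within the scatter) in this assay so this is the first isolated change at this place, and it leaves the two compounds indistinguishable on this read-out. Compound 3 gives 4600 nM and compound 4, with the same 4-fluorobenzyl group, gives 920 nM so the higher number of compound 3 cannot rest on the place of the fluorine alone. Nothing shown here explains why the 3-fluorobenzyl and 4-fluorobenzyl compounds read alike.

Whether the fluorine itself counts at all stays open, since the compounds shown offer no comparison with a plain benzyl group, a 2-fluorobenzyl group, a 4-chlorobenzyl group or a 4-methoxybenzyl group on the same ring nitrogen. As far as these compounds go, it is also open how a longer chain, such as 2-phenylethyl in place of the benzyl arm, would read with the warhead kept.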